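This account rests on a few compounds, and the source may have more. Where it says the series, first, only, none or still open, it means among the compounds named here.

Two long-chain amides have been measured so far in a functional assay on OVCAR-3 cells (Homo sapiens) for antiproliferative activity, read by sulforhodamine B assay, with a stated time of 48 h; on this read-out higher numbers stand for weaker inhibition of growth and lower numbers for stronger inhibition of growth. Compound 1 `CCCCCC[C@@H](O)C/C=C\CCCCCCCC(=O)N[C@@H](C)c1ccccc1` gives 11.1 ug/mL, and compound 2 `CCCCCCCCCCCCCCCCCC(=O)N1CCOCC1` gives 43.3 ug/mL. Compound 2 therefore holds the higher of the two numbers, which here means the weaker inhibition of growth, and its gap to compound 1 lies beyond the usual scatter.

The next compound, compound 3 `CCCCCCCCCCCCCCCC(=O)N1CCOCC1`, differs from compound 2 in one place only: hydrogen in place of ethyl on a saturated chain carbon, ten or more bonds along the chain from a carbonyl carbon. Going by the values given here, no measured pair yet shows what a change of this kind does in this assay, so the expectation rests on compound 2 alone, at 43.3 ug/mL. Any shift in this assay is expected to stay within the scatter, with perhaps a slight drift towards a lower number. The estimated step of a 1.2-fold lower number from compound 2 to compound 3 (0.09 log units; within the scatter) is therefore small. Compound 3 is expected at 35 ug/mL, with an estimated range of 17 ug/mL to 70 ug/mL.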

Compound 3, concentration for 50% growth inhibition: 33.1 ug/mL
Beside the measured number, compound 3's estimate is 1.1-fold (0.02 log units) above it; low and high end bracket the measured number.
By their numbers in this assay, from the lowest: compound 1; then compounds 3 and 2 (each within the scatter of the next).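

In this assay this first measured pair of its kind puts a number on the change: hydrogen in place of ethyl on a saturated chain carbon, ten or more bonds along the chain from a carbonyl carbon, gives a 1.3-fold lower number from compound 2 to compound 3 (0.12 log units; within the scatter) and nothing larger. At this far position, then, compound 2 and compound 3 cannot be told apart by their inhibition of growth, and this pair gives no sign that the ethyl matters for the read-out, though a single pair is thin support for any general statement about the chain. No measurement available here accounts for the two compounds reading alike.

Still open, going by these compounds, is whether a longer chain, or an amine or a carboxylic acid on this same chain carbon, would also stay within the scatter or would move the number clearly in either direction. Also open, on these data alone, is whether hydrogen in place of ethyl would read the same way on a chain that carries a hydroxyl group and a double bond, as the chain of compound 1 does.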